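A heteroaryl exchange on the carbonyl carbon

The compounds below may be only part of what the source reports. "The series", "measured", "known", "first", "only" and "open" are said of these compounds alone.

Three amides share a sulfonyl-bearing benzylamide arm and differ in the aromatic group on the carbonyl carbon. Compound 1 `Cn1c(C(=O)NCc2ccc(S(=O)(=O)c3ccccc3)cc2)cc2cnccc21` reaches only a limit in a functional assay on A2780 cells (Homo sapiens) for inhibition, read by sulforhodamine B assay, with a stated time of 72 h (a lower number here means a stronger inhibitor, a higher number a weaker inhibitor), giving > 10000 nM. Compound 2 `O=C(NCc1ccc(S(=O)(=O)c2cc(F)cc(F)c2)cc1)c1cc2ccncc2o1` gives 9 nM in this assay. Compound 3 `O=C(NCc1ccc(S(=O)(=O)N2CCCCC2)cc1)c1cc2cnccc2s1` gives 1600 nM in this assay, the higher of the two numbers recorded, with compound 2 sitting far lower, beyond the scatter. Compound 4 `O=C(NCc1ccc(S(=O)(=O)N2CCCCC2)cc1)c1ccn2cncc2c1` has not been measured. It differs from compound 3 only on the carbonyl carbon: a group of 9 heavy atoms (7 carbon, 2 nitrogen; one five-membered aromatic ring with 2 hetero atoms, one six-membered aromatic ring with 1 hetero atom) in place of a group of 9 heavy atoms (7 carbon, 1 nitrogen, 1 sulfur; one five-membered aromatic ring with 1 hetero atom, one six-membered aromatic ring with 1 hetero atom), on a carbonyl carbon. Going by the values given here, no measured pair isolates this exchange, so the size of the step is uncertain; a modest shift toward a weaker inhibitor is expected. Compound 4 is estimated at 3000 nM in this assay, within a range from 700 nM to 15000 nM. That estimate implies an expected step of a 1.9-fold higher number from compound 3 to compound 4 (0.27 log units; within the scatter).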

Compound 4, half-maximal inhibitory concentration: > 10000 nM
Compound 4: no number, only a limit (the forecaster's own chance of this, stated with the estimate: 25%); middle value at least 3.3-fold (0.52 log units) from the limit.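

Holding the sulfonyl-bearing benzylamide arm fixed, the exchange on the carbonyl carbon gives the first comparison here that differs in one place: in this assay it produces an at least 6.2-fold higher number from compound 3 to compound 4 (0.79 log units; beyond the scatter). The group on the carbonyl carbon therefore matters even with its heavy-atom and hydrogen-bond acceptor counts unchanged. The value of compound 4 is a limit, not a number: the limit of > 10000 nM in this assay, at which 2 of the 4 values shown sit.

On these data alone, it remains open whether a plain phenyl group on the carbonyl carbon would fall nearer compound 3 or compound 4. Also open, as far as these compounds go, is whether this exchange behaves alike with the difluorophenyl sulfonyl arm of compound 2.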